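This account rests on a few compounds, and the source may have more. Where it says the series, first, only, none or still open, it means among the compounds named here.

Measured compounds:
- compound 1, `Cc1cccc2c1nc(COc1ccc(Cl)cc1)n2CCCC1CCN(C)CC1`: in an assay on AV12 cells for binding affinity to Neuropeptide Y receptor type 1 (Homo sapiens) (a higher number here means a weaker inhibitor, a lower number a stronger inhibitor), compound 1 gives 52 nM
- compound 2, `CCOC(=O)CCCN1CCC(CCCn2c(COc3ccc(Cl)cc3)nc3c(C)cccc32)CC1`: in this assay compound 2 gives 29 nM
- compound 3, `Cc1cccc2c1nc(COc1ccc(Cl)cc1)n2CCCC1CCN(CCCC(=O)O)CC1`: in this assay compound 3 gives 1630 nM

Compound 3 has the highest number of the three, so it is the weakest inhibitor here; the nearest to it is compound 1, and compound 2 is furthest away. Compound 4, `Cc1cccc2c1nc(COc1ccc(Cl)cc1)n2CCCC1CCN(CCCC(=O)N2CCCCC2)CC1`, differs from compound 3 in one place: piperidin-1-yl in place of hydroxy on a carbonyl carbon. Among the measured compounds shown here, two measured steps bear on this change. The step of a 56-fold higher number from compound 2 to compound 3 (1.75 log units; beyond the scatter) shows what happens when the ethyl on that same carbonyl is replaced by hydrogen, leaving the carboxy group. The step of a 31-fold higher number from compound 1 to compound 3 (1.50 log units; beyond the scatter) shows that adding the 2-carboxyethyl chain to compound 1 costs a similar amount, while the step of a 1.8-fold lower number from compound 1 to compound 2 (0.25 log units; within the scatter) shows that the 2-(ethoxycarbonyl)ethyl chain costs nothing beyond the scatter. Compound 4 again carries a carbonyl without a hydroxy on it, so a large step downward is expected, roughly undoing the loss, because the step of a 56-fold higher number from compound 2 to compound 3 (1.75 log units; beyond the scatter) went the other way. The expected step is a 41-fold lower number from compound 3 to compound 4 (1.61 log units; beyond the scatter). The estimate for compound 4 is 40 nM, with a range from 12 nM to 160 nM.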

Compound 4, inhibition constant: 21 nM
Compound 4: middle estimate off by 1.9-fold (0.28 log units), on the high side; the measured number falls inside the stated range.
By their numbers in this assay, from the lowest: compounds 4, 2 and 1 (each within the scatter of the next, the first and the last beyond it); then compound 3.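

Putting piperidin-1-yl in place of hydroxy on the carbonyl carbon gives a 78-fold lower number from compound 3 to compound 4 (1.89 log units; beyond the scatter) in this assay, so a carbonyl at the end of this chain does not need to be an ester for the number to stay low. Swapping ethoxy for piperidin-1-yl gives a 1.4-fold lower number from compound 2 to compound 4 (0.14 log units; within the scatter) and so makes no difference beyond the scatter, which leaves the carboxy compound as the only one of the four that stands apart. Adding the whole 2-((piperidin-1-yl)carbonyl)ethyl chain in place of hydrogen gives a 2.5-fold lower number from compound 1 to compound 4 (0.39 log units; beyond the scatter) and is the only chain addition here with a modest gain beyond the scatter.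

No measurement here explains these steps. Open, from the compounds shown here alone, is whether a morpholine amide, a simple dimethylamide or a longer chain to the carbonyl would behave like the piperidin-1-yl amide.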